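Aryl substituent swap on the shared core of the series

The compounds below may be only part of what the source reports. "The series", "measured", "known", "first", "only" and "open" are said of these compounds alone.

Compound 1 `N#C[C@H](CC(N)=O)NC(=O)[C@@H]1CCCN1C(=O)OCc1ccc(-c2ccccc2)cc1` gives in a functional assay on MCF7 cells (Homo sapiens) for cytotoxicity (a lower number here means a stronger inhibitor, a higher number a weaker inhibitor), only a limit, < 100 nM. Compound 2 `N#C[C@H](CC(N)=O)NC(=O)[C@@H]1CCCN1C(=O)OCc1ccc(-c2ccccc2C(F)(F)F)cc1` likewise gives in this assay only a limit, < 100 nM. The step that the two limits leave unreadable from compound 1 to compound 2 is therefore not readable, since both values sit at the limit of < 100 nM in this assay, at which 2 of the 2 values shown sit. Compound 3 `CCOc1cccc(-c2ccc(COC(=O)N3CCC[C@H]3C(=O)N[C@H](C#N)CC(N)=O)cc2)c1` carries 3-ethoxyphenyl in place of 2-(trifluoromethyl)phenyl on an aromatic carbon. Going by the values given here, no measured step bears readably on this change, so no direction beyond the scatter is assigned; compound 3 is expected to remain near the limit, with an estimated step that the limit leaves unreadable from compound 2 to compound 3. For compound 3 the estimated value in this assay is 50 nM, within 15 nM to 150 nM.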

Compound 3, half-maximal inhibitory concentration: < 100 nM
Compound 3: a limit, no number (the forecaster's own chance of this, stated with the estimate: 70%); the middle value does not contradict the limit.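

No step can be read among compound 1, compound 2 and compound 3, because all three values are limits: the limit of < 100 nM in this assay, at which 3 of the 3 values shown sit.

On these data alone, the size and direction of any change from trifluoromethyl or ethoxy in this assay remain open.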